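Adding a Second Chlorine to a Weakly Cytotoxic Compound

The source may hold more compounds than are shown below. What is called first, only, known or untested is meant among the compounds shown, and "the series" means these compounds.

In a functional assay on HeLa cells (Homo sapiens) for cytotoxicity, read by sulforhodamine B assay, with a stated time of 48 h (a higher number here means a weaker inhibitor, a lower number a stronger inhibitor), three compounds have been measured:

compound 1 `O=C(c1cccnc1)c1ccccc1O` gives 33000 nM
compound 2 `O=C(c1cccnc1)c1cc(Cl)ccc1O` gives 24000 nM
compound 3 `C=CCOc1ccc(Cl)cc1C(=O)c1cccnc1` gives 75000 nM

Compound 2 differs from compound 1 by chloro in place of hydrogen on an aromatic carbon and this brought a 1.4-fold lower number from compound 1 to compound 2 (0.14 log units; within the scatter). Compound 3 then differs from compound 2 by an allyl in place of hydrogen on an oxygen on an aromatic ring, which brought a 3.1-fold higher number from compound 2 to compound 3 (0.49 log units; beyond the scatter). Between compound 1 and compound 3 the difference of the two cores is not broken down here; compound 3 simply has the highest number of the three.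

Compound 4 `C=CCOc1c(Cl)cc(Cl)cc1C(=O)c1cccnc1` has not been measured. It differs from compound 3 by chloro in place of hydrogen on an aromatic carbon. The same kind of change was made from compound 1 to compound 2, but the surroundings differ: there the chlorine entered meta to a group of 8 heavy atoms and para to a hydroxy group, here it enters ortho to an allyloxy group, meta to a chloro group and meta to a group of 8 heavy atoms. Because the earlier step was a 1.4-fold lower number from compound 1 to compound 2 (0.14 log units; within the scatter), a step of about the same size is expected here, a 1.4-fold lower number from compound 3 to compound 4 (0.13 log units; within the scatter). Compound 4 is therefore estimated at 55000 nM, between 22000 nM and 140000 nM.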

Compound 4, half-maximal inhibitory concentration: 34000 nM
Beside the measured number, compound 4's estimate is 1.6-fold (0.21 log units) above it; the range from low to high includes it.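

Replacing hydrogen with chloro on the aromatic carbon ortho to an allyloxy group gave a 2.2-fold lower number from compound 3 to compound 4 (0.34 log units; beyond the scatter) in this assay. Going by these compounds alone, the same change on the two cores gave steps that cannot be told apart: the same change on two cores in this assay, a 1.4-fold lower number (0.14 log units; within the scatter) from compound 1 to compound 2 and a 2.2-fold lower number (0.34 log units; beyond the scatter) from compound 3 to compound 4, 1.6-fold (0.21 log units) apart, within the scatter of two such steps This shows that, across these two pairs, the step size did not clearly depend on the core, although only the newer step stands clear of the scatter on its own; it does not show that the step would be the same on other cores, and with only two pairs and the chlorine entering different surroundings in each, the effect of the core cannot be separated from that of the position.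

Going by these compounds, it remains open whether a methoxy group or an amine in place of this chlorine would give a step of similar size, and whether a longer chain in place of the allyl group would alter the step. On these data alone, it is also open what this chlorine would do on compound 2, which carries a free hydroxy group instead of the allyloxy group.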